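Shortening an alkenyl chain on a shared two-ring core

This account rests on a few compounds, and the source may have more. Where it says the series, first, only, none or still open, it means among the compounds named here.

Three measured compounds share a core in which a five-membered aromatic ring bearing a methyl group is joined to a benzene ring that carries an alkenyloxy chain. Compound 1 `C=CCCCCOc1ccccc1-c1cnc(OCCCC=C)n1C` gives 3000 nM in a functional assay on A549 cells (Homo sapiens) for inhibition, read by colorimetric assay and MTT assay, with a stated time of 72 h; a lower number here means a stronger inhibitor, a higher number a weaker inhibitor. Compound 2 `C=CCCCCCOc1ncc(-c2ccccc2OCCCCC=C)n1C` gives 62000 nM. Compound 3 `C=CCCCCOc1ccccc1-c1cnc(S(=O)(=O)c2ccccc2)n1C` gives 38000 nM. The step from compound 2 to compound 1 is vinyl in place of but-3-en-1-yl on a saturated chain carbon, three bonds along the chain from an oxygen on an aromatic ring, and it made a 21-fold lower number from compound 2 to compound 1 (1.32 log units; beyond the scatter). The cores of compound 2 and compound 3 differ by phenylsulfonyl in place of (hept-6-en-1-yl)oxy on an aromatic carbon, a change that made a 1.6-fold lower number from compound 2 to compound 3 (0.21 log units; within the scatter); from compound 1 to compound 3 the step is a 13-fold higher number from compound 1 to compound 3 (1.10 log units; beyond the scatter).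

Compound 4 `C=CCCOc1ccccc1-c1cnc(S(=O)(=O)c2ccccc2)n1C` has not been measured. It differs from compound 3 by vinyl in place of but-3-en-1-yl on a saturated chain carbon, two bonds along the chain from an oxygen on an aromatic ring. This is the same kind of change as that from compound 2 to compound 1, but the place differs: there the change sat three bonds along the chain from the ring oxygen, here it sits two bonds along. Because the earlier shortening gave a 21-fold lower number from compound 2 to compound 1 (1.32 log units; beyond the scatter), a lower number is expected for compound 4. Since the chain and its position are not the same, a smaller step is expected for compound 4, estimated at a 3.2-fold lower number from compound 3 to compound 4 (0.50 log units; beyond the scatter). Compound 4 is therefore estimated at 12000 nM, with a range from 4000 nM to 40000 nM.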

Compound 4, half-maximal inhibitory concentration: 73000 nM
For compound 4 the middle estimate is 6.1-fold (0.78 log units) below the measured one; the measured number lies above the stated range.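

In this assay, shortening the chain on the phenylsulfonyl core does not separate the two compounds, with a 1.9-fold higher number from compound 3 to compound 4 (0.28 log units; within the scatter), so here it leaves the number inside the usual scatter. The large drop seen on the core of compound 1 therefore did not carry over to this core, and the two steps clearly disagree: the same change on two cores in this assay, a 21-fold lower number (1.32 log units; beyond the scatter) from compound 2 to compound 1 and a 1.9-fold higher number (0.28 log units; within the scatter) from compound 3 to compound 4, 40-fold (1.60 log units) apart, beyond the scatter of two such steps. This shows that the effect of this shortening depends on its setting, but it does not show what in that setting matters, since the two steps differ both in the rest of the molecule and in where the change sits, three bonds along the chain in one case and two in the other.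

Still open, as far as these compounds go, is how the same shortening would read on a third core, for example one carrying a carboxylic acid or an amine in place of phenylsulfonyl. Also open is whether a saturated hexyl chain would behave like the alkenyl chains shown here.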